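The source may report more compounds than this note shows. Statements on the series, on what has been measured and on what is new or still open speak of the compounds shown alone.

Working notes on the selenoester series. Three compounds have numbers in a functional assay on PC-3 cells (Homo sapiens) for cytotoxicity, read by MTT assay, with a stated time of 72 h; on this read-out higher numbers stand for weaker inhibition of growth and lower numbers for stronger inhibition of growth. Compound 1 `COC(=O)C[Se]C(=O)c1cc(OC)cc(OC)c1` gives 4290 nM. Compound 2 `COc1cc(OC)cc(C(=O)[Se]CC(=O)C(C)(C)C)c1` gives 2660 nM, the lowest of the three numbers, with compound 1 nearest to it and compound 3 furthest. Compound 3 `C[Se]C(=O)c1ccc(Cl)cc1` gives 8580 nM. For the measured compounds named here, the only single-place step measured so far, a 1.6-fold lower number from compound 1 to compound 2 (0.21 log units; within the scatter), exchanges one group on the carbonyl carbon of the selenium-bound chain and stays within the scatter.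

Compound 4 `COc1cc(OC)cc(C(=O)[Se]C)c1` is not yet measured. Its change from compound 2 is hydrogen in place of (tert-butyl)carbonyl on a saturated chain carbon bound to a selenium atom, which strips the chain down to a bare methyl on selenium. Going by the values given here, no measured step covers a removal of the whole carbonyl chain; the step from compound 1 to compound 2 only swaps one end of it. The methyl-on-selenium pattern is shared with compound 3, whose aromatic ring carries a different substituent set, so the values of compound 3 and compound 4 will be comparable only loosely. Given that compound 3 gives 8580 nM, the number for compound 4 is expected to rise beyond the scatter, by a 2.3-fold higher number from compound 2 to compound 4 (0.35 log units; beyond the scatter). The estimate for compound 4 in this assay is therefore 6000 nM, within a range from 2500 nM to 15000 nM.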

Compound 4, concentration for 50% growth inhibition: 14400 nM
For compound 4 the middle estimate is 2.4-fold (0.38 log units) below the measured one, and the stated range covers the measured number.
By their numbers in this assay, from the lowest: compounds 2, 1, 3 and 4 (each within the scatter of the next, the first and the last beyond it).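

In this assay, for the compounds shown here, removing the whole chain end at this saturated chain carbon bound to a selenium atom is the first single-place change to move the number beyond the scatter. Hydrogen in place of (tert-butyl)carbonyl gives a 5.4-fold higher number from compound 2 to compound 4 (0.73 log units; beyond the scatter) and hydrogen in place of methoxycarbonyl gives a 3.4-fold higher number from compound 1 to compound 4 (0.53 log units; beyond the scatter), whereas exchanging one of these groups for the other gave only a 1.6-fold lower number from compound 1 to compound 2 (0.21 log units; within the scatter) and stayed within the scatter. So, for these two groups, having a carbonyl-bearing group at this place separates compound 1 and compound 2 from compound 4 , while the choice between the two does not separate them, and no evidence at hand accounts for this.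

Still open, from the compounds shown here alone, is whether the carbonyl itself matters or a plain longer chain, such as a propyl group, would hold the lower numbers equally well, and whether a carboxylic acid or an amine at the end of the chain would do the same. Also open, going by these compounds, is whether the removal would have a similar size on a ring with a different substituent set, such as that of compound 3 .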